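A larger group on the sulfonyl sulfur of compound 1

The compounds below may be only part of what the source reports. "The series", "measured", "known", "first", "only" and "open" are said of these compounds alone.

Compound 1 `CS(=O)(=O)Cc1nc2c(Sc3ccc(Cl)cc3)cc(Cl)cn2c1[N+](=O)[O-]` gives > 31200 nM as a limit
Compound 2 `O=[N+]([O-])c1c(CS(=O)(=O)c2ccccc2)nc2c(Nc3ccc(Cl)cc3)cc(Cl)cn12` gives > 3900 nM as a limit
Compound 3 `CS(=O)(=O)Cc1nc2c(Br)cc(Cl)cn2c1[N+](=O)[O-]` gives 45000 nM as a measured number

In an ADME assay on HepG2 cells (Homo sapiens) for cytotoxicity, read by MTT assay, with a stated time of 72 h (a lower number here means that less compound is tolerated, a higher number that more compound is tolerated), compound 1 stands at > 31200 nM as a limit and not as a number. Its exact place is therefore unknown, and any step starting from it is hard to size.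

Compound 4 `O=[N+]([O-])c1c(CS(=O)(=O)C2CCCCC2)nc2c(Sc3ccc(Cl)cc3)cc(Cl)cn12` changes one group of compound 1: cyclohexyl in place of methyl on a sulfonyl sulfur.

Within the data shown here, the only measured step is a step that the limit leaves unreadable from compound 1 to compound 3 (bromo in place of (4-chlorophenyl)sulfanyl on an aromatic carbon). It gives no size and concerns a different group, so it says little about this change.

Compound 2 also carries a ring on its sulfonyl sulfur, though it differs elsewhere too, and it shows > 3900 nM as a limit.

The expected size therefore rests on the limit of compound 1 at > 31200 nM and is small, with a slight lean toward less compound tolerated. The estimated step is an at least 1.5-fold lower number from compound 1 to compound 4 (0.19 log units; that floor lies within the scatter) and carries wide uncertainty. For compound 4 the expected value is 20000 nM as an estimate. The estimated range for compound 4 runs from 5000 nM to 60000 nM and this assay may well report only a limit again.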

Compound 4, half-maximal cytotoxic concentration: > 31200 nM
Compound 4 gave a limit, no number (the forecaster's own chance of this, stated with the estimate: 65%); middle value at least 1.5-fold (0.19 log units) from the limit.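

In this assay, among these compounds, compound 1 and compound 4 each give only a limit and not a number, so no step between them can be read: the limit of > 31200 nM in this assay, at which 2 of the 4 values shown sit. The compounds shown leave open whether cyclohexyl in place of methyl on a sulfonyl sulfur changes how much compound is tolerated at all.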